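Working notes: hydroxyphenyl in place of chlorophenyl

A few compounds are considered here, and "the series" means these few. Any claim that something is new, unique, unknown or untested is made for them only; others in the source may bear on it.

Three compounds of the series have numbers in an assay on mitochondria (strain BALB/c) for inhibition of glycerol-3-phosphate acyltransferase 1, mitochondrial (Mus musculus), read by scintillation counting, with a stated time of 10 min; a higher number here means a weaker inhibitor, a lower number a stronger inhibitor. Compound 1 `CCCCCCCCS(=O)(=O)Nc1cc(-c2ccc(-c3ccccc3)cc2)ccc1C(=O)O` gives 13500 nM, compound 2 `CCCCCCCCS(=O)(=O)Nc1cc(-c2ccccc2F)ccc1C(=O)O` gives 47200 nM, and compound 3 `CCCCCCCCS(=O)(=O)Nc1ccc(-c2ccccc2Cl)cc1C(=O)O` gives 14400 nM. Compound 3 holds the second highest of the three numbers: its value and that of compound 1 lie within the scatter of each other, while compound 2 shows a higher number, beyond the scatter. Compound 4 `CCCCCCCCS(=O)(=O)Nc1ccc(-c2ccc(O)cc2)cc1C(=O)O` is not yet measured in this assay. It differs from compound 3 in one place: 4-hydroxyphenyl in place of 2-chlorophenyl on an aromatic carbon. Going by the values given here, no step between measured compounds that differ in a single place exists, so the size of this change is open. The expected step in this assay is a 1.5-fold higher number from compound 3 to compound 4 (0.18 log units; within the scatter), a modest rise near the edge of the scatter. For compound 4 the expected value in this assay is 22000 nM, with a range from 7000 nM to 65000 nM.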

Compound 4, half-maximal inhibitory concentration: 47300 nM
Estimate against measurement, compound 4: 2.2-fold (0.33 log units) below; measured number inside the range.
By their numbers in this assay, from the lowest: compounds 1 and 3 (each within the scatter of the next); then compounds 2 and 4 (each within the scatter of the next).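

In this assay, 4-hydroxyphenyl in place of 2-chlorophenyl gives a 3.3-fold higher number from compound 3 to compound 4 (0.52 log units; beyond the scatter), the only step between compounds shown that differ in a single place. This position on the shared core therefore responds to a change of its aryl group, though the step is modest. Nothing available explains the rise.

The step changes both substituent and ring position, so it remains open which of the two accounts for it. A 4-chlorophenyl or 2-hydroxyphenyl group at this place would separate them.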